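The source may hold more compounds than are shown below. What is called first, only, known or untested is meant among the compounds shown, and "the series" means these compounds.

The series was examined in a functional assay on MGC-803 cells (Homo sapiens) for inhibition, read by MTT assay, with a stated time of 72 h; on this read-out lower numbers stand for stronger inhibition and higher numbers for weaker inhibition. Compound 1 `O=C(CSc1nc(Nc2ccccc2)c2ccccc2n1)Nc1ccccc1Br` carries an unsubstituted phenyl on the amine nitrogen and a bromophenyl amide; in this assay compound 1 gives 18600 nM. Compound 2 `C=CC(=O)Nc1cccc(NC(=O)CSc2nc(Nc3cccc(F)c3)c3ccccc3n2)c1` replaces that phenyl with a 3-fluorophenyl and carries an acrylamide on the amide-bearing ring; in this assay compound 2 gives 6250 nM, the lower of the two numbers measured, and the gap to compound 1 lies beyond the usual scatter.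

Compound 3 `C=CC(=O)Nc1cccc(NC(=O)CSc2nc(Nc3ccc(F)cc3)c3ccccc3n2)c1` has not yet been measured. It differs from compound 2 only in one place: 4-fluorophenyl in place of 3-fluorophenyl on a nitrogen on an aromatic ring. Within the data shown here, no pair of measured compounds that differs only in this way is available, so nothing in the data says how moving the fluorine around the ring alters the read-out. Such a change is expected to be small, with no clear direction, so the step from compound 2 to compound 3 is estimated as a 1.0-fold lower number from compound 2 to compound 3 (0.02 log units; within the scatter). On that basis compound 3 is expected to give about 6000 nM in this assay, within a range from 2500 nM to 15000 nM.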

Compound 3, half-maximal inhibitory concentration: 8290 nM
Compound 3: the middle estimate sits 1.4-fold (0.14 log units) below what was measured, within the range that was stated.
By their numbers in this assay, from the lowest: compounds 2 and 3 (each within the scatter of the next); then compound 1.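

Among these compounds, compound 3 supplies the first pair that differs in one place only, and in this assay the change from 3-fluorophenyl to 4-fluorophenyl on a nitrogen on an aromatic ring is a 1.3-fold higher number from compound 2 to compound 3 (0.12 log units; within the scatter). For this pair, then, the read-out does not separate the two fluorine placements, a point that compound 1 and compound 2 could not address since they differ in more than one place. The data offer no independent measurement that would explain this outcome at the level of the compounds themselves.

What the compounds shown leave open is whether this position responds to anything other than a shift of the fluorine, for instance a chlorine atom, a methoxy group, an amine or a carboxylic acid on the same ring, as one pair with a single substituent says nothing about those groups. Also open, going by these compounds, is how much the fluorine and the acrylamide each contribute to the gap between compound 1 and the other two, since compound 1 differs from compound 2 and from compound 3 in more than one place.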